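Pyridine for Phenyl in a Hydrazone Series

The source may report more compounds than this note shows. Statements on the series, on what has been measured and on what is new or still open speak of the compounds shown alone.

Compound 1 `COc1ccc(/C(C)=N/Nc2nc3ccccc3nc2Cc2ccccc2)cc1` gives 89 nM in an assay on isolated protein for inhibition of Amine oxidase [flavin-containing] A (Homo sapiens), read by spectrophotometry; a higher number here means a weaker inhibitor, a lower number a stronger inhibitor. Compound 2 `C(=N/Nc1nc2ccccc2nc1Cc1ccccc1)\c1ccccc1` gives 81 nM in this assay. Compound 3 `C/C(=N\Nc1nc2ccccc2nc1Cc1ccccc1)c1ccccc1` gives 79 nM in this assay.

The three numbers sit together: the step of a 1.0-fold lower number from compound 2 to compound 3 (0.01 log units; within the scatter) and the step of a 1.1-fold lower number from compound 1 to compound 3 (0.05 log units; within the scatter) are both within the scatter, so compound 2 stands alongside compound 1 and compound 3 with no separation that can be trusted. Compound 4 `C/C(=N\Nc1nc2ccccc2nc1Cc1ccccc1)c1ccccn1` is not yet measured. It differs from compound 2 by a group of 9 heavy atoms (7 carbon, 2 nitrogen; one six-membered aromatic ring with 1 hetero atom) in place of a group of 8 heavy atoms (7 carbon, 1 nitrogen; one six-membered aromatic ring of carbon only), on a nitrogen on an aromatic ring. Within the data shown here, no measured step swaps the carbon-only ring for a ring with a hetero atom, so there is no direct guide. The small steps seen so far suggest a change that is expected to stay modest, a 1.2-fold higher number from compound 2 to compound 4 (0.09 log units; within the scatter). Compound 4 is therefore estimated at 100 nM, within 40 nM to 250 nM.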

Compound 4, half-maximal inhibitory concentration: 91 nM
For compound 4 the middle estimate is 1.1-fold (0.04 log units) above the measured one; low and high end bracket the measured number.
By their numbers in this assay, from the lowest: compounds 3, 2, 1 and 4 (each within the scatter of the next).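

Compound 4 shows that a ring with a hetero atom can stand on this carbon with a double bond to nitrogen with no separation that can be trusted. Pyridin-2-yl in place of phenyl gives a small step (a 1.2-fold higher number from compound 3 to compound 4 (0.06 log units; within the scatter)), as does pyridin-2-yl in place of 4-methoxyphenyl (a 1.0-fold higher number from compound 1 to compound 4 (0.01 log units; within the scatter)), and the swap of the whole group on a nitrogen on an aromatic ring also stays within the scatter (a 1.1-fold higher number from compound 2 to compound 4 (0.05 log units; within the scatter)). Nothing measured here bears on why these numbers stay together.

Still open, on these data alone, is whether an amine or a carboxylic acid on this ring would move the number in this assay beyond the scatter.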